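Working notes: formyl for methyl on the aryl arm

The source may report more compounds than this note shows. Statements on the series, on what has been measured and on what is new or still open speak of the compounds shown alone.

Compound 1 `O=Cc1ccc(-c2cn3ccnc3c(-c3ccc4ncn(C5CCCCC5)c4c3)n2)cc1`: 56.5%
Compound 2 `CCc1ccc(-c2cn3ccnc3c(-c3ccc4ncn(Cc5ccccc5)c4c3)n2)cc1`: 47.9%
Compound 3 `Cc1cccc(-c2cn3ccnc3c(-c3ccc4ncn(Cc5ccccc5)c4c3)n2)c1`: 10.1%

In a functional assay on SK-MEL-5 cells (Homo sapiens) for inhibition, read by sulforhodamine B assay, with a stated time of 48 h, tested at 10 uM (a lower number here means less inhibition, a higher number more inhibition at the concentration tested (going by the name of the read-out)), compound 3 stands lowest of the three measured numbers; compound 2 lies well above it and compound 1 further still, both gaps beyond the scatter. Among the compounds with values here, the only directly measured step, a number 37.8 percentage points lower from compound 2 to compound 3 (beyond the scatter), is large and downward. Compound 4 `O=Cc1ccc(-c2cn3ccnc3c(-c3ccc4ncn(Cc5ccccc5)c4c3)n2)cc1` is compound 3 with 4-formylphenyl in place of 3-methylphenyl on an aromatic carbon. Within the data shown here, no measured step carries this exact change. Among the measured compounds shown here, the group that leaves is the one whose arrival in compound 3 brought that large drop, and compound 1, bearing the entering 4-formylphenyl on a different core, gives 56.5%. A large upward step is therefore expected, a number 39.9 percentage points higher from compound 3 to compound 4 (beyond the scatter). Compound 4 is estimated at 50%, in a range from 30% to 70%.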

Compound 4, a percentage reported as inhibition, at one concentration (the size of the read-out at that concentration, not a potency): 56.5%
Estimate against measurement, compound 4: 6.5 percentage points below; low and high end bracket the measured number.
By their numbers in this assay, from the lowest: compound 3; then compounds 2, 1 and 4 (each within the scatter of the next).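

In this assay the aryl arm answers strongly to this change, with a number 46.4 percentage points higher from compound 3 to compound 4 (beyond the scatter) on going to 4-formylphenyl. Formyl in place of ethyl gives a number 8.6 percentage points higher from compound 2 to compound 4 (within the scatter), so 4-formylphenyl and 4-ethylphenyl are not told apart here. Benzyl in place of cyclohexyl on the aromatic nitrogen gives no change at the digits printed from compound 1 to compound 4 (within the scatter), so these two groups are not told apart either, at least with 4-formylphenyl on the arm.

On these data alone, how an amine or a carboxylic acid in place of formyl would read stays open. Nothing available explains these steps.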